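A few compounds are considered here, and "the series" means these few. Any claim that something is new, unique, unknown or untested is made for them only; others in the source may bear on it.

In a functional assay on MDA-MB-231 cells (Homo sapiens) for cytotoxicity, read by MTT assay, with a stated time of 72 h (a higher number here means a weaker inhibitor, a lower number a stronger inhibitor), compound 1 `CN(C)Cc1ccc2nc(NC(=O)N/N=C/c3cn(Cc4ccc(C(C)(C)C)cc4)c4ccccc34)sc2c1` gives 2230 nM and compound 2 `CC1CCN(Cc2ccc3nc(NC(=O)N/N=C/c4cn(Cc5ccccc5Cl)c5ccccc45)sc3c2)CC1` gives 1360 nM as its value, so the two stand within the usual scatter of each other. Compound 3 `CC1CCN(Cc2ccc3nc(NC(=O)N/N=C/c4cn(Cc5ccc(C(C)(C)C)cc5)c5ccccc45)sc3c2)CC1` has 4-(tert-butyl)phenyl in place of 2-chlorophenyl on a saturated chain carbon bound to an aromatic nitrogen and otherwise matches compound 2. Within the data shown here, no measured pair shows this change alone, but compound 1 also carries 4-(tert-butyl)benzyl and gives 2230 nM in this same range. The expected step is a 1.3-fold higher number from compound 2 to compound 3 (0.12 log units; within the scatter) towards a higher number, within the scatter. The estimate for compound 3 is 1800 nM with an expected range from 800 nM to 4000 nM in this assay.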

Compound 3, half-maximal inhibitory concentration: 3880 nM
Compound 3: the middle estimate sits 2.2-fold (0.33 log units) below what was measured; measured number inside the range.
By their numbers in this assay, from the lowest: compounds 2, 1 and 3 (each within the scatter of the next, the first and the last beyond it).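

In this assay, 4-(tert-butyl)benzyl in place of 2-chlorobenzyl on the aromatic nitrogen can now be read alone, as a 2.9-fold higher number from compound 2 to compound 3 (0.46 log units; beyond the scatter), so the group at this position does alter the number. With 4-(tert-butyl)benzyl held fixed, 4-methylpiperidin-1-yl in place of dimethylamino gives a 1.7-fold higher number from compound 1 to compound 3 (0.24 log units; within the scatter), so that exchange does not separate the two compounds. Nothing at hand gives a reason for either step. From the compounds shown here alone, how an unsubstituted benzyl or a 4-methoxybenzyl would read at this position remains open. So does whether the step from 2-chlorobenzyl holds with dimethylamino on the other side.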